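Carbamoyl for cyano on the weaker-configured alcohol

This account rests on a few compounds, and the source may have more. Where it says the series, first, only, none or still open, it means among the compounds named here.

Going by the values given here, compound 3 `COc1ccc(/C=C2\c3cc(OC)c(OC)c(OC)c3CC[C@H]2O)cc1C#N` gives 200 nM in a functional assay on HT-29 cells (Homo sapiens) for inhibition, read by MTT assay (a higher number here means a weaker inhibitor, a lower number a stronger inhibitor), the highest of the three numbers so far. Compound 2 `COc1ccc(/C=C2\c3cc(OC)c(OC)c(OC)c3CC[C@@H]2O)cc1N` gives 160 nM, within the scatter of compound 3, while compound 1 `COc1ccc(/C=C2\c3cc(OC)c(OC)c(OC)c3CC[C@@H]2O)cc1C#N` gives 5 nM. The step of a 40-fold higher number from compound 1 to compound 3 (1.60 log units; beyond the scatter) rests on the fact that compounds 1 and 3 differ only in the configuration as drawn alone. Compound 4 `COc1ccc(/C=C2\c3cc(OC)c(OC)c(OC)c3CC[C@H]2O)cc1C(N)=O` differs from compound 3 by carbamoyl in place of cyano on an aromatic carbon, on the same aromatic carbon where a 32-fold higher number from compound 1 to compound 2 (1.51 log units; beyond the scatter) was seen. That step bears on the change only loosely, since carbamoyl is not amino, but it suggests that replacing the cyano costs activity. A moderate weakening is therefore expected for compound 4, as a 3.0-fold higher number from compound 3 to compound 4 (0.48 log units; beyond the scatter). Compound 4 is estimated at 600 nM, within 150 nM to 3000 nM.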

Compound 4, half-maximal inhibitory concentration: 550 nM
The estimate for compound 4 lay 1.1-fold (0.04 log units) above the measured number, within the range that was stated.
By their numbers in this assay, from the lowest: compound 1; then compounds 2 and 3 (each within the scatter of the next); then compound 4.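

Working on the alcohol configuration of compound 3, the aromatic carbon that carries the nitrile accepts carbamoyl in this assay at a modest cost: a 2.8-fold higher number from compound 3 to compound 4 (0.44 log units; beyond the scatter). Going by these compounds alone, the only earlier change at this carbon was on the configuration of compound 1, so this is the first reading of a change there on the other configuration. Nothing at hand gives a measured basis for this step.

On these data alone, how carbamoyl reads on the configuration of compound 1 stays open. So does the effect of a carboxylic acid or an aminomethyl group at this carbon.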